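Hydroxymethyl in Place of Methoxy on the Fused Ring

The compounds below may be only part of what the source reports. "The series", "measured", "known", "first", "only" and "open" are said of these compounds alone.

In a functional assay on HEK293 cells for agonist activity at Free fatty acid receptor 1 (Homo sapiens), read by fluorescence and calcium flux, with a stated time of 10 min (on this read-out higher numbers stand for larger maximal responses and lower numbers for smaller maximal responses), compound 2 `CC#C[C@@H](CC(=O)O)c1ccc(OC[C@H]2COc3ccc(OC)cc3O2)cc1` gives 91%, the higher of the two measured numbers; compound 1 `CC#C[C@@H](CC(=O)O)c1ccc(OC[C@H]2COc3ccc(C)cc3O2)cc1` gives 78%, and the step of a number 13 percentage points higher from compound 1 to compound 2 (beyond the scatter) is the only one measured. Compound 3 `CC#C[C@@H](CC(=O)O)c1ccc(OC[C@H]2COc3ccc(CO)cc3O2)cc1` differs from compound 2 by hydroxymethyl in place of methoxy on an aromatic carbon. Within the data shown here, the one measured step concerns a different exchange on that aromatic carbon and bears only loosely here; no measured compound carries a hydroxymethyl. With the exchange untested, compound 3 is expected to stay close to that level, a number 6 percentage points lower from compound 2 to compound 3 (within the scatter) being within the scatter or a small loss. The estimate for compound 3 is 85%, range 70% to 100%.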

Compound 3, largest response reached (Emax), in percent of the reference or control that the assay uses: 42%
Compound 3: middle estimate off by 43 percentage points, on the high side, and the stated range ends above it.
By their numbers in this assay, from the lowest: compound 3; then compound 1; then compound 2.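

In this assay, the maximal response at this aromatic carbon falls sharply once hydroxymethyl is present: methoxy to hydroxymethyl gives a number 49 percentage points lower from compound 2 to compound 3 (beyond the scatter), and hydroxy in place of hydrogen on a saturated chain carbon bound to an aromatic carbon gives a number 36 percentage points lower from compound 1 to compound 3 (beyond the scatter). Methoxy and hydroxymethyl both have 2 heavy atoms, so that count does not set the response at this position. Nothing available explains the loss. Still open, going by these compounds, is whether the drop is particular to hydroxymethyl or extends to other groups here. An aminomethyl, a carboxylic acid or a longer hydroxyalkyl chain on this carbon would test that.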